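From compound 1 to compound 3: what to expect

This account rests on a few compounds, and the source may have more. Where it says the series, first, only, none or still open, it means among the compounds named here.

Measured in a functional assay on HCT-116 cells (Homo sapiens) for cytotoxicity, read by MTT assay; a higher number here means a weaker inhibitor, a lower number a stronger inhibitor:
Compound 1 `CSc1nc(NCc2ccc(C(=O)Nc3ccccc3N)cc2)n[nH]1`: 600 nM
Compound 2 `Nc1ccccc1NC(=O)c1ccc(CNc2nc3ccccc3[nH]2)cc1`: 300 nM

Compound 1 gives 600 nM and compound 2 gives 300 nM here, and these two values lie within the scatter of each other, so neither compound can be ranked above the other. Compound 3 `Cn1ccnc1SCc1ccc(C(=O)Nc2ccccc2N)cc1` has not been measured yet. It keeps the core of compound 1 and differs in one place: (1-methyl-1H-imidazol-2-yl)sulfanyl in place of (5-(methylsulfanyl)-1H-1,2,4-triazol-3-yl)amino on a saturated chain carbon bound to an aromatic carbon in all. Put in words, (1-methyl-1H-imidazol-2-yl)sulfanyl stands in place of (5-(methylsulfanyl)-1H-1,2,4-triazol-3-yl)amino on a saturated chain carbon bound to an aromatic carbon.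

Among the compounds with values here, only one measured step bears on this. It is a 2.0-fold lower number from compound 1 to compound 2 (0.30 log units; within the scatter) and it also gave up the 5-(methylsulfanyl)-1H-1,2,4-triazol-3-yl group, there for 1H-benzimidazol-2-yl on an amine nitrogen. Within the data shown here, no measured compound carries (1-methyl-1H-imidazol-2-yl)sulfanyl, so the evidence is thin. In this assay no step beyond the scatter is expected, and no direction can be favoured. The expected step is a 1.2-fold lower number from compound 1 to compound 3 (0.08 log units; within the scatter) by this estimate. Compound 3 is expected near 500 nM with an estimated range of 150 nM to 1700 nM for now.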

Compound 3, half-maximal inhibitory concentration: 5000 nM
Estimate against measurement, compound 3: 10-fold (1.00 log units) below; measured number outside the range, above it.
By their numbers in this assay, from the lowest: compounds 2 and 1 (each within the scatter of the next); then compound 3.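

In this assay, the group on the saturated chain carbon bound to an aromatic carbon now clearly matters: the earlier swap stayed within the scatter, whereas this change gives an 8.3-fold higher number from compound 1 to compound 3 (0.92 log units; beyond the scatter). This is more than one small edit, as the amino link gives way to a sulfanyl link, the five-membered aromatic ring goes from 3 hetero atoms to 2, and the entering group has 0 hydrogen-bond donors where the leaving group has 2. Nothing available explains the weaker result or shows which of these differences accounts for it.

The compounds shown therefore leave the link and the ring tangled together: (1-methyl-1H-imidazol-2-yl)amino, which keeps the amino link of compound 1 and carries the ring of compound 3, would help separate the two. On these data alone, it also remains open how a plain amine or a hydroxyl group on the same chain carbon would read in this assay, which would show how much of the five-membered aromatic ring is needed at all.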